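The source may hold more compounds than are shown below. What is called first, only, known or untested is meant among the compounds shown, and "the series" means these compounds.

Measured compounds:
Compound 1 `O=C(Cn1cnc([N+](=O)[O-])n1)Nc1ccc(Oc2ccc(Cl)cc2)cc1` gives 80000 nM in an ADME assay on cells (Peritoneal macrophage cell, Mus musculus) for cytotoxicity; a higher number here means a weaker inhibitor, a lower number a stronger inhibitor.
Compound 2 `O=C(Cn1cnc([N+](=O)[O-])n1)Nc1ccc(Oc2ccc(F)cc2)cc1` gives 84000 nM in this assay.

Compound 2 stands level with compound 1: the step of a 1.1-fold higher number from compound 1 to compound 2 (0.02 log units; within the scatter) is within the scatter, so the two numbers cannot be told apart. Compound 3 `O=C(Cn1ccnc1[N+](=O)[O-])Nc1ccc(Oc2ccc(F)cc2)cc1` is the next compound, and it differs from compound 2 in one place: 2-nitro-1H-imidazol-1-yl in place of 3-nitro-1H-1,2,4-triazol-1-yl on a saturated chain carbon bound to a carbonyl carbon. Within the data shown here, the only measured step, from compound 1 to compound 2, alters a halogen on an aromatic carbon and leaves the nitro-bearing five-membered ring untouched, so it gives no direct guide to the present change; what it does show is that a single small change here left this assay unmoved. Among the measured compounds shown here, no measured compound carries the 2-nitro-1H-imidazol-1-yl ring, so the expectation rests on that absence of movement. For compound 3 a number of 84000 nM in this assay is expected, between 40000 nM and 180000 nM. The expected step of no change at the digits printed from compound 2 to compound 3 (within the scatter) is therefore taken to lie within the scatter.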

Compound 3, half-maximal inhibitory concentration: > 84000 nM
Compound 3 ended at the assay's limit (the forecaster's own chance of this, stated with the estimate: 20%); the middle value lies on the limit itself.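

In this assay, compound 3 gives a limit and not a number: the limit of > 84000 nM in this assay, at which 1 of the 3 values shown sits. With 2-nitro-1H-imidazol-1-yl in place of 3-nitro-1H-1,2,4-triazol-1-yl, on a saturated chain carbon bound to a carbonyl carbon, the result shows only a number no lower from compound 2 to compound 3 (the limit leaves the size open). Among these compounds, the earlier pair changed only a halogen, so this is the first sign that exchanging the nitro-bearing ring did not produce a stronger inhibitor in this assay.

As far as these compounds go, how far compound 3 lies past its limit remains open. Also open, from the compounds shown here alone, is whether a group without the nitro, such as an unsubstituted imidazol-1-yl ring or an amine, on this same chain carbon would lower the number.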